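The source may hold more compounds than are shown below. What is called first, only, known or untested is meant among the compounds shown, and "the series" means these compounds.

Three compounds share one core and differ only in the group on an amine nitrogen in a ring. Compound 1 `CC(C)N1CCN(c2nc(Nc3ccc(C#N)c(C(F)(F)F)c3)nc(Oc3ccnc4ccccc34)n2)CC1` carries isopropyl there; in a functional assay on DU-145 cells (Homo sapiens) for cytotoxicity, read by sulforhodamine B assay, with a stated time of 48 h (a higher number here means a weaker inhibitor of growth, a lower number a stronger inhibitor of growth), compound 1 gives > 100000 nM, which is a limit of the assay rather than a number. Compound 2 `N#Cc1ccc(Nc2nc(Oc3ccnc4ccccc34)nc(N3CCN(c4cccc(Cl)c4Cl)CC3)n2)cc1C(F)(F)F` carries 2,3-dichlorophenyl, and in this assay compound 2 gives > 100000 nM, again a limit. Compound 3 `N#Cc1ccc(Nc2nc(Oc3ccnc4ccccc34)nc(N3CCN(c4cccc(C(F)(F)F)c4)CC3)n2)cc1C(F)(F)F` carries 3-(trifluoromethyl)phenyl and is the only one of the three with a measured number: in this assay compound 3 gives 38700 nM. The move from isopropyl to this aryl group gave an at least 2.5-fold lower number from compound 1 to compound 3 (0.41 log units; beyond the scatter), and the move from the dichlorophenyl compound gave an at least 2.5-fold lower number from compound 2 to compound 3 (0.41 log units; beyond the scatter); both comparisons rest on (the limit of > 100000 nM in this assay, at which 2 of the 3 values shown sit). Compound 4 `N#Cc1ccc(Nc2nc(Oc3ccnc4ccccc34)nc(N3CCN(c4ccc(F)cc4)CC3)n2)cc1C(F)(F)F` differs from compound 3 by 4-fluorophenyl in place of 3-(trifluoromethyl)phenyl on an amine nitrogen in a ring. Since compound 1 and compound 2 both sit at the limit of > 100000 nM in this assay, at which 2 of the 3 values shown sit, compound 4 is expected to come out weaker than compound 3, with a 1.8-fold higher number from compound 3 to compound 4 (0.26 log units; within the scatter). Compound 4 is estimated to give 70000 nM, within a range from 25000 nM to 200000 nM.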

Compound 4, concentration for 50% growth inhibition: > 100000 nM
Compound 4 gave a limit, no number; the forecaster's own chance of this, stated with the estimate: 40%; at least 1.4-fold (0.15 log units) between middle value and limit.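

Putting 4-fluorophenyl in place of 3-(trifluoromethyl)phenyl gives an at least 2.5-fold higher number from compound 3 to compound 4 (0.41 log units; beyond the scatter) in this assay, so among the aryl groups shown, a measured number is not a feature of every aryl group at this position. With compound 4 added, the 3-(trifluoromethyl)phenyl group of compound 3 is the only group shown here that gives a number rather than a limit. The steps among compound 1, compound 2 and compound 4 cannot be read, because each of these compounds sits at a limit and no order among them can be drawn: the limit of > 100000 nM in this assay, at which 3 of the 4 values shown sit.

The compounds shown leave open whether 4-(trifluoromethyl)phenyl or 3-fluorophenyl would give a number, which would help separate the choice of substituent from its place on the phenyl ring. They also leave open what an unsubstituted phenyl would give at this nitrogen.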